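Second fluoro on the benzyl ring of compound 3

A few compounds are considered here, and "the series" means these few. Any claim that something is new, unique, unknown or untested is made for them only; others in the source may bear on it.

Measured compounds:
- compound 1, `O=[N+]([O-])c1ccc2[nH]c(Cc3ccc(Oc4ccccc4)cc3)nc2c1`, 1200 nM
- compound 2, `CCS(=O)(=O)Nc1ccc2[nH]c(Cc3ccc(Oc4ccccc4)cc3)nc2c1`, 2800 nM
- compound 3, `Oc1ccc2[nH]c(CN3CCC(Cc4ccccc4F)CC3)nc2c1`, 730 nM

All three values come from an assay on membranes from brain for binding affinity to Adrenergic receptor alpha-1 (Rattus norvegicus); on this read-out lower numbers stand for stronger inhibition and higher numbers for weaker inhibition. Compound 3 and compound 1 sit within the usual scatter of each other, so no order between them can be read; compound 2 stands beyond the scatter from both. Among the compounds with values here, the only step that joins two measured compounds is a 2.3-fold higher number from compound 1 to compound 2 (0.37 log units; beyond the scatter), and it concerns a substituent on the shared core, not the side chain that is changed here.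

Compound 4 is `Oc1ccc2[nH]c(CN3CCC(Cc4c(F)cccc4F)CC3)nc2c1`. It differs from compound 3 by fluoro in place of hydrogen on an aromatic carbon, which reads, one bond further out, as 2-fluorophenyl to 2,6-difluorophenyl. Within the data shown here, no measured pair bears on this change, so the expectation rests on compound 3 alone. The step from compound 3 is expected to be a 1.0-fold lower number from compound 3 to compound 4 (0.02 log units; within the scatter), that is, nothing clearly beyond the scatter. For compound 4 in this assay the estimated value is 700 nM, with a range from 300 nM to 1700 nM.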

Compound 4, half-maximal inhibitory concentration: 2600 nM
Estimate against measurement, compound 4: 3.7-fold (0.57 log units) below, outside the stated range (above it).
By their numbers in this assay, from the lowest: compounds 3 and 1 (each within the scatter of the next); then compounds 4 and 2 (each within the scatter of the next).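

In this assay, going from 2-fluorophenyl to 2,6-difluorophenyl brings a 3.6-fold higher number from compound 3 to compound 4 (0.55 log units; beyond the scatter) and so weakens inhibition, which shows that this ring does not tolerate every swap of hydrogen for fluoro. Within the data shown here, this is the first measured step on this side chain, since the only earlier step concerned a substituent on the shared core. No measurement at hand speaks to the reason for this loss.

From the compounds shown here alone, whether the loss comes from fluoro itself or from any group in this place stays open; a chloro, methyl or methoxy group there would help separate the two. A plain phenyl ring with no fluoro would show whether the fluoro already present in compound 3 helps or hurts.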